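Swapping the ring on the amine nitrogen of compound 3

A few compounds are considered here, and "the series" means these few. Any claim that something is new, unique, unknown or untested is made for them only; others in the source may bear on it.

Compound 1 `CN(c1nc2ccc(NC(=O)CCc3ccc(C(F)(F)F)cc3)cc2[nH]1)C1CCOC1` gives 27 nM in an assay on CHO-K1 cells for displacement of a labelled ligand from melanin-concentrating hormone receptor 1 (Homo sapiens), read by scintillation counting; on this read-out higher numbers stand for weaker inhibition and lower numbers for stronger inhibition.
Compound 2 `CC(C)N(C)c1ccc2nc(NC(=O)CCc3ccc(C(F)(F)F)cc3)ccc2n1` gives 375 nM in this assay.
Compound 3 `CC(=O)N1CCC(N(C)c2nc3ccc(NC(=O)CCc4ccc(C(F)(F)F)cc4)cc3[nH]2)C1` gives 30 nM in this assay.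

Compound 3 stands second highest of the three numbers; it sits with compound 1, as the step of a 1.1-fold higher number from compound 1 to compound 3 (0.05 log units; within the scatter) shows, and far from compound 2, whose core differs. Compound 4 `CN(c1nc2ccc(NC(=O)CCc3ccc(C(F)(F)F)cc3)cc2[nH]1)C1CCCC1` carries the change (cyclopentyl in place of 1-acetylpyrrolidin-3-yl on a nitrogen on an aromatic ring). Among the compounds with values here, the only measured step touching this nitrogen, a 1.1-fold higher number from compound 1 to compound 3 (0.05 log units; within the scatter), changed the number within the scatter, so ring swaps here have so far made little difference. Compound 4 is therefore expected to show a step of a 1.2-fold higher number from compound 3 to compound 4 (0.07 log units; within the scatter), nothing beyond the scatter. Compound 4 is estimated at 35 nM, with a range from 12 nM to 100 nM.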

Compound 4, half-maximal inhibitory concentration: 4 nM
For compound 4 the middle estimate is 8.8-fold (0.94 log units) above the measured one; the measured number lies below the stated range.
By their numbers in this assay, from the lowest: compound 4; then compounds 1 and 3 (each within the scatter of the next); then compound 2.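

In this assay the ring on this nitrogen turns out to matter: cyclopentyl brings a 7.5-fold lower number from compound 3 to compound 4 (0.88 log units; beyond the scatter) and a 6.8-fold lower number from compound 1 to compound 4 (0.83 log units; beyond the scatter) while the two rings carrying a hetero atom stay level with each other (a 1.1-fold higher number from compound 1 to compound 3 (0.05 log units; within the scatter)). Among these three compounds, then, only the ring of carbon only stands apart, and this is a pattern from a single example. No measurement at hand explains the drop. From the compounds shown here alone, whether a smaller carbon ring such as cyclobutyl or a larger one such as cyclohexyl on this nitrogen would keep the number this low remains open.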